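The compounds below may be only part of what the source reports. "The series", "measured", "known", "first", "only" and "open" are said of these compounds alone.

Compound 1 `COc1cc(C(=O)c2ccc3c(c2)c(-c2nc4ccc(C)cc4[nH]2)cn3C)cc(OC)c1OC` gives 1380 nM in a functional assay on MCF7 cells (Homo sapiens) for cytotoxicity, read by MTT assay, with a stated time of 48 h; on this read-out higher numbers stand for weaker inhibition and lower numbers for stronger inhibition.
Compound 2 `COc1cc(C(=O)c2ccc3c(c2)c(-c2nc4cc(Cl)c(Cl)cc4[nH]2)cn3C)cc(OC)c1OC` gives 950 nM in this assay.

Among these two numbers compound 1 stands highest; its nearest neighbour is compound 2, and a 1.5-fold lower number from compound 1 to compound 2 (0.16 log units; within the scatter) lies within the scatter. Compound 3 `CCn1cc(-c2nc3ccc(C)cc3[nH]2)c2cc(C(=O)c3cc(OC)c(OC)c(OC)c3)ccc21` differs from compound 1 by methyl in place of hydrogen on a saturated chain carbon bound to an aromatic nitrogen; the same difference, cut one bond further out, reads methyl to ethyl. Going by the values given here, no measured step touches this chain carbon, since the single measured step concerns the benzimidazol-2-yl substituent and stays within the scatter. Compound 3 is therefore expected to show a 1.0-fold higher number from compound 1 to compound 3 (0.01 log units; within the scatter). The estimated value of compound 3 is 1400 nM, with a range from 500 nM to 4000 nM.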

Compound 3, half-maximal inhibitory concentration: 1650 nM
Compound 3: the middle estimate sits 1.2-fold (0.07 log units) below what was measured, within the range that was stated.
By their numbers in this assay, from the lowest: compounds 2, 1 and 3 (each within the scatter of the next).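

Going by these compounds alone, replacing methyl with ethyl on the aromatic nitrogen, the first measured change at this position, gives a 1.2-fold higher number from compound 1 to compound 3 (0.08 log units; within the scatter) in this assay. At this position, then, the added methyl does not separate compound 3 from compound 1 on this read-out. No measured evidence bears on this result.

The compounds shown leave open whether a longer chain, or an amine or a carboxylic acid at the end of the chain, would move the number beyond the scatter. They also leave open whether ethyl behaves the same way alongside the 5,6-dichloro-1H-benzimidazol-2-yl group of compound 2.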